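Methyl for Chloro on the Terminal Anilide Ring

The source may report more compounds than this note shows. Statements on the series, on what has been measured and on what is new or still open speak of the compounds shown alone.

compound 1 `CN(C)C(=O)c1cc2cnc(Nc3ccc(NC(=O)C4(C(=O)Nc5ccccc5)CC4)cc3)nc2n1C1CCCC1`: 93.9%
compound 2 `CN(C)C(=O)c1cc2cnc(Nc3ccc(NC(=O)C4(C(=O)Nc5cccc(Cl)c5)CC4)cc3)nc2n1C1CCCC1`: 92.6%

In a functional assay on T47D cells (Homo sapiens) for inhibition, read by CCK-8 assay, with a stated time of 72 h, tested at 10 uM (a lower number here means less inhibition of growth, a higher number more inhibition of growth at the concentration tested), compound 2 gives the lower of the two numbers, with compound 1 the nearest and within the scatter of it. Compound 3 `Cc1cccc(NC(=O)C2(C(=O)Nc3ccc(Nc4ncc5cc(C(=O)N(C)C)n(C6CCCC6)c5n4)cc3)CC2)c1` differs from compound 2 by methyl in place of chloro on an aromatic carbon. Among the compounds with values here, only one measured step bears on this change: a number 1.3 percentage points lower from compound 1 to compound 2 (within the scatter), which put chloro in place of hydrogen on the same aromatic carbon and stayed within the scatter. Because a number 1.3 percentage points lower from compound 1 to compound 2 (within the scatter) was that small, compound 3 is expected to show a step of a number 0.6 percentage points lower from compound 2 to compound 3 (within the scatter), nothing beyond the scatter. Compound 3 is therefore estimated at 92%, between 84% and 99%.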

Compound 3, percent growth inhibition at one concentration: 95.3%
Compound 3: the middle estimate sits 3.3 percentage points below what was measured, within the range that was stated.
By their numbers in this assay, from the lowest: compounds 2, 1 and 3 (each within the scatter of the next).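

In this assay methyl at this position gives a number 2.7 percentage points higher from compound 2 to compound 3 (within the scatter) and a number 1.4 percentage points higher from compound 1 to compound 3 (within the scatter) and so stands with chloro and hydrogen within the scatter. The three groups on this ring, one of them now a carbon substituent, are therefore not told apart at the single concentration tested. Nothing measured here gives a reason for this.

As far as these compounds go, whether an amine, a carboxylic acid or a longer chain at this place would leave the number unchanged remains open. So does whether methyl, chloro and hydrogen would separate in a dose-response measurement.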